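Removing a Methyl from an Aryl Sulfone

A few compounds are considered here, and "the series" means these few. Any claim that something is new, unique, unknown or untested is made for them only; others in the source may bear on it.

Measured compounds:
compound 1 `Cc1cccc(S(=O)(=O)c2ccc(CNC(=O)c3cc4cnccc4[nH]3)cc2)c1` — 49%
compound 2 `O=C(NCc1ccc(S(=O)(=O)c2ccccc2)cc1)c1cc(-c2cccnc2)no1` — 69%
compound 3 `O=C(NCc1ccc(S(=O)(=O)N2CCCCC2)cc1)c1cc2cccnc2s1` — no single number

In an ADME assay on microsomes from liver (Homo sapiens) for metabolic stability, read by LC-MS, with a stated time of 30 min, tested at 1 uM (a lower number here means that less of the compound is left, a higher number that more of the compound is left), compound 1 gives 49%, the lowest of the two numbers in hand. Compound 2 gives 69%, a gap beyond the scatter. For compound 3 this assay reports "below limit of detection" (no number reported), so no single number is given for it.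

Compound 4 `O=C(NCc1ccc(S(=O)(=O)c2ccccc2)cc1)c1cc2cnccc2[nH]1` differs from compound 1 by hydrogen in place of methyl on an aromatic carbon. No change of exactly this kind has been measured in this series, so any expectation rests on compound 1 and compound 2 alone. A step within or just beyond the scatter is expected, upward, so that compound 4 is estimated at 56% (range 36% to 76%), a shift of a number 7 percentage points higher from compound 1 to compound 4 (within the scatter).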

Compound 4, percent of the compound remaining: 75%
Compound 4: middle estimate off by 19 percentage points, on the low side; the measured number falls inside the stated range.
By their numbers in this assay, from the lowest: compound 1; then compounds 2 and 4 (each within the scatter of the next).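

Replacing 3-methylphenyl with phenyl gives a number 26 percentage points higher from compound 1 to compound 4 (beyond the scatter) in this assay, so the loss of one heavy atom at this position is enough to move the read-out. For the compounds shown here, this is the first step between compounds that differ in one place, and it rests on this single pair. No measurement at hand accounts for the step.

From the compounds shown here alone, whether the same change carries over to the cores of compound 2 or compound 3 remains open. So does the outcome of placing a fluorine, a chlorine or a methoxy group on this aromatic carbon.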